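This account rests on a few compounds, and the source may have more. Where it says the series, first, only, none or still open, it means among the compounds named here.

Compound 2 `NC(=O)c1c(NC(=O)c2ccccc2)sc2c1CCN(C(=S)Nc1ccccc1Cl)C2` and compound 1 `COc1ccccc1NC(=S)N1CCc2c(sc(NC(=O)c3ccccc3Cl)c2C(N)=O)C1` share the same core and differ only in where a methoxy and a chlorine sit on their two outer rings. In a functional assay on HeLa cells (Homo sapiens) for antiproliferative activity, with a stated time of 24 h (a higher number here means a weaker inhibitor, a lower number a stronger inhibitor), compound 2 gives only a limit of the assay, > 50000 nM. In this assay compound 1 likewise gives only a limit, > 50000 nM. Both values stand at the limit of > 50000 nM in this assay, at which 2 of the 2 values shown sit. Compound 3 `COc1ccccc1C(=O)Nc1sc2c(c1C(N)=O)CCN(C(=S)Nc1ccccc1Cl)C2` differs from compound 2 by methoxy in place of hydrogen on an aromatic carbon. Among the measured compounds shown here, no measured pair shows what this change does, so no step beyond the scatter is expected in this assay in either direction. Compound 3 is therefore expected to give about 50000 nM, between 20000 nM and 50000 nM. The step of a number no higher from compound 2 to compound 3 (the limit leaves the size open) is an estimate only.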

Compound 3, half-maximal inhibitory concentration: > 50000 nM
Compound 3: no number, only a limit; the forecaster's own chance of this, stated with the estimate: 85%; the middle value lies on the limit itself.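

In this assay, among the compounds shown here, compound 3 gives only a limit, > 50000 nM, as compound 2 does, and no step between the two can be read. The compounds shown leave open whether methoxy in place of hydrogen on an aromatic carbon changes this activity at all.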